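A few compounds are considered here, and "the series" means these few. Any claim that something is new, unique, unknown or untested is made for them only; others in the source may bear on it.

Measured compounds:
compound 1, `CN(C(=S)SCc1ccc(C(=O)Nc2ccccc2N)cc1)c1cccnc1`, 26.5%
compound 2, `CC1CCN(C(=S)SCc2ccc(C(=O)Nc3ccccc3N)cc2)CC1`, 32.7%
compound 3, `CN(Cc1ccncc1)C(=S)SCc1ccc(C(=O)Nc2ccccc2N)cc1`, 31.4%

All three were tested in a functional assay on A-375 cells (Homo sapiens) for antiproliferative activity, read by CCK-8 assay, with a stated time of 72 h, tested at 2 uM; a higher number here means a stronger effect of the compound at the concentration tested, a lower number a weaker effect. Compound 3 stands second highest of the three numbers; its nearest neighbour is compound 2, with a number 1.3 percentage points lower from compound 2 to compound 3 (within the scatter), and its furthest is compound 1, with a number 4.9 percentage points higher from compound 1 to compound 3 (within the scatter). The remaining pair, compound 1 and compound 2, show a number 6.2 percentage points higher from compound 1 to compound 2 (within the scatter). So the three numbers all lie within the scatter of one another.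

Compound 4 is `CN(Cc1cccnc1)C(=S)SCc1ccc(C(=O)Nc2ccccc2N)cc1`. It differs from compound 3 by pyridin-3-yl in place of pyridin-4-yl on a saturated chain carbon bound to an amide-type nitrogen. Going by the values given here, the step that bears most directly on this change is the one from compound 1 to compound 3, where a pyridin-3-yl attached straight to the amide-type nitrogen gave way to a (pyridin-4-yl)methyl, and that step stayed within the scatter; the two steps involving compound 2 were likewise within the scatter. No movement beyond the scatter is therefore expected for this assay, and the step of a number 1.4 percentage points lower from compound 3 to compound 4 (within the scatter) is estimated to be small. Compound 4 is accordingly expected to give about 30%, with a range from 20% to 40%.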

Compound 4, a percentage reported as inhibition, at one concentration (the size of the read-out at that concentration, not a potency): 39.4%
For compound 4 the middle estimate is 9.4 percentage points below the measured one; measured number inside the range.
By their numbers in this assay, from the lowest: compounds 1, 3, 2 and 4 (each within the scatter of the next, the first and the last beyond it).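

In this assay, pyridin-3-yl in place of pyridin-4-yl on a saturated chain carbon bound to an amide-type nitrogen gives a number 8 percentage points higher from compound 3 to compound 4 (within the scatter), and the exchange of 4-methylpiperidin-1-yl for methyl((pyridin-3-yl)methyl)amino on a thiocarbonyl carbon gives a number 6.7 percentage points higher from compound 2 to compound 4 (within the scatter), so neither change separates the compounds. What is new is a number 12.9 percentage points higher from compound 1 to compound 4 (beyond the scatter): the (pyridin-3-yl)methyl of compound 4 gives the only step among these compounds to pass the scatter, whereas the (pyridin-4-yl)methyl of compound 3 stayed within it of compound 1. Nothing available explains this result.

On these data alone, it remains open how (pyridin-2-yl)methyl, benzyl or a longer chain such as 2-(pyridin-3-yl)ethyl would read at this place. With one concentration per compound, the read-out also says nothing of potency.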